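Chloro in Place of Bromo on a Sulfonamide Ring

The source may hold more compounds than are shown below. What is called first, only, known or untested is meant among the compounds shown, and "the series" means these compounds.

Compound 1 `O=C1CCCCC1S(=O)(=O)Nc1ccccc1Br`: 15.4%
Compound 2 `Cc1cccc(S(=O)(=O)C2CCCCCC2=O)c1C`: 22.9%

Both compounds were tested in a functional assay on HL-60 cells (Homo sapiens) for antiproliferative activity, read by MTT assay, tested at 100 ug/mL; a higher number here means more inhibition at the concentration tested (going by the name of the read-out), a lower number less inhibition. Compound 1 gives 15.4%, and compound 2 gives 22.9%, a number within the usual scatter of it, so the two cannot be told apart.

Compound 3 `O=C1CCCCC1S(=O)(=O)Nc1ccccc1Cl` differs from compound 1 in one place: chloro in place of bromo on an aromatic carbon. Going by the values given here, no measured pair shows what this change does. In this assay the step from compound 1 to compound 3 is therefore expected to be small, in either direction and not beyond the scatter: a number 0.6 percentage points higher from compound 1 to compound 3 (within the scatter). Compound 3 is expected to give 16%, between 6% and 28%.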

Compound 3, a percentage reported as inhibition, at one concentration (the size of the read-out at that concentration, not a potency): 0.29%
Compound 3: middle estimate off by 15.7 percentage points, on the high side; the whole stated range lies above it.
By their numbers in this assay, from the lowest: compound 3; then compounds 1 and 2 (each within the scatter of the next).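

Bromo and chloro each count as a single heavy atom with no hydrogen-bond donors or acceptors, yet exchanging them on this aromatic carbon is not neutral in this assay: the change gives a number 15.1 percentage points lower from compound 1 to compound 3 (beyond the scatter). At the concentration tested, compound 3 gives 0.29%, almost no inhibition. No measurement shown here accounts for this difference.

The compounds shown leave open what a fluoro, methyl or methoxy group on this aromatic carbon would give. They also leave open whether the same exchange has a similar effect on another core.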